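The source may hold more compounds than are shown below. What is called first, only, known or untested is meant among the compounds shown, and "the series" means these compounds.

Compound 1, with the structure `CN(C)C(=O)C[C@H](CSc1ccccc1)Nc1c(C(=O)N/N=C/c2ccc(Br)s2)cnc2c(C(F)(F)F)cccc12`, carries a 5-bromothiophen-2-yl group on a carbon with a double bond to nitrogen. In an ADME assay on Vero cells (Chlorocebus sabaeus) for cytotoxicity, read by MTT assay, with a stated time of 72 h (on this read-out higher numbers stand for weaker inhibition and lower numbers for stronger inhibition), compound 1 gives > 62.5 ug/mL, which is a limit of the assay and not a number. Compound 2, with the structure `COc1ccc(/C=N/NC(=O)c2cnc3c(C(F)(F)F)cccc3c2N[C@@H](CSc2ccccc2)CC(=O)N(C)C)cc1O`, differs from compound 1 by 3-hydroxy-4-methoxyphenyl in place of 5-bromothiophen-2-yl on a carbon with a double bond to nitrogen. In this assay compound 2 gives > 62.5 ug/mL, again a limit rather than a number. The step that the two limits leave unreadable from compound 1 to compound 2 therefore cannot be read as a size, because the limit of > 62.5 ug/mL in this assay, at which 2 of the 3 values shown sit, holds both of its values.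

Compound 3, with the structure `CN(C)C(=O)C[C@H](CSc1ccccc1)Nc1c(C(=O)N/N=C/c2ccc(Br)s2)cnc2ccc(F)cc12`, has a different core from compound 1; the difference between the two cores is not broken down here. In this assay compound 3 has "not determined" (no result reported), so no result is available for it.

Compound 4, with the structure `COc1ccc(/C=N/NC(=O)c2cnc3ccc(F)cc3c2N[C@@H](CSc2ccccc2)CC(=O)N(C)C)cc1O`, has not yet been measured. It differs from compound 3 by 3-hydroxy-4-methoxyphenyl in place of 5-bromothiophen-2-yl on a carbon with a double bond to nitrogen, which is the same change as that from compound 1 to compound 2, made at the same kind of place. For the measured compounds named here, since no number exists for compound 3, no step from compound 3 to compound 4 can be estimated. What can be said rests on the two measured compounds, both of which sit at the same limit. On that basis compound 4 is expected to give 80 ug/mL, with a likely range from 40 ug/mL to 200 ug/mL, and most probably to return only a limit as well.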

Compound 4, half-maximal inhibitory concentration: > 62.5 ug/mL
Compound 4 ended at the assay's limit; the forecaster's own chance of this, stated with the estimate: 85%; the middle value lies beyond the limit too.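

In this assay compound 4 gives > 62.5 ug/mL, which is a limit of the assay and not a number. For the compounds shown here, compound 3 has no number to set against this limit, so no step from compound 3 to compound 4 can be read. The compounds shown leave open where the true values of compound 1, compound 2 and compound 4 lie, and whether swapping 5-bromothiophen-2-yl for 3-hydroxy-4-methoxyphenyl changes the value at all.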